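A few compounds are considered here, and "the series" means these few. Any claim that something is new, unique, unknown or untested is made for them only; others in the source may bear on it.

Within the data shown here, compound 1, with the structure `COc1ccccc1/C=C/C(=O)c1ccc(OCC(=O)N[C@H]2CCOC2=O)cc1`, is the one member of this small set for which a number rather than a limit is known. In a functional assay on DU-145 cells (Homo sapiens) for antiproliferative activity, read by MTT assay, with a stated time of 72 h (a higher number here means a weaker inhibitor, a lower number a stronger inhibitor), compound 1 gives 10100 nM. The two companions sit elsewhere. Compound 2, with the structure `Cc1ccc(C(C)C)c(OCCSC(=S)N[C@H]2CCOC2=O)c1`, reaches only the limit of the assay, > 64000 nM. Compound 3, with the structure `Cc1cc(Cl)ccc1NCC(=O)N[C@H]1CCOC1=O`, likewise stops at the limit, > 64000 nM. So compound 1 stands alone with a measured value, while the limit of > 64000 nM in this assay, at which 2 of the 3 values shown sit, marks where the other two rest, and no step between measured compounds can be drawn from them.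

Among the measured compounds shown here, compound 4, with the structure `O=C(COc1ccc(C(=O)/C=C/c2cccc(Cl)c2)cc1)N[C@H]1CCOC1=O`, keeps the whole core of compound 1 and changes only one ring: 3-chlorophenyl in place of 2-methoxyphenyl on a double-bonded chain carbon bound to a double-bonded chain carbon. Nothing in the shown data speaks to how such an exchange on this core affects the read-out of this assay, so the step from compound 1 to compound 4 is expected to stay within the usual scatter, in no particular direction, which is what a 1.1-fold lower number from compound 1 to compound 4 (0.05 log units; within the scatter) expresses. Compound 4 is therefore estimated at 9000 nM, with a plausible range from 3000 nM to 27000 nM.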

Compound 4, half-maximal inhibitory concentration: 3700 nM
Estimate against measurement, compound 4: 2.4-fold (0.39 log units) above; the range from low to high includes it.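

Among these compounds, until now the core of compound 1 had only a single measured value, so nothing showed whether the group on a double-bonded chain carbon bound to a double-bonded chain carbon affects the read-out. In this assay, placing 3-chlorophenyl there instead of 2-methoxyphenyl gives a 2.7-fold lower number from compound 1 to compound 4 (0.44 log units; beyond the scatter), so this position does respond to a change, although the step is modest. The exchange removes the oxygen-bearing methoxy group and brings in chlorine in a single move, and nothing shown measures a property that would account for the step.

The two compounds therefore cannot separate the loss of the methoxy group from the gain of the chlorine, and a single pair cannot show whether other groups at this position would move the number further, or in which direction. A plain phenyl group carrying neither chlorine nor methoxy would be a useful reference point, while a phenyl group bearing an amine or a carboxylic acid would test this position with quite different atoms, and neither appears among the compounds shown.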